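Working notes: phenyl to 4-chlorophenyl in the series

This account rests on a few compounds, and the source may have more. Where it says the series, first, only, none or still open, it means among the compounds named here.

Entries so far in a functional assay on HCT-116 cells (Homo sapiens) for cytotoxicity, read by MTT assay, with a stated time of 48 h; on this read-out lower numbers stand for stronger inhibition and higher numbers for weaker inhibition
compound 1 `C#CCOc1ccc2oc(=O)ccc2c1` has the entry "not determined" (no result reported)
compound 2 `O=c1ccc2cc(OCc3cc(-c4ccccc4)no3)ccc2o1` has the entry "not determined" (no result reported)
compound 3 `O=c1ccc2cc(OCc3cc(-c4cccc5ccccc45)no3)ccc2o1` has the value 51500 nM

Compound 2 has no single number in this assay and cannot be placed against compound 3. The same holds for compound 1. Among the compounds with values here, the series therefore offers no measured step, and compound 3 is the only numerical anchor at 51500 nM for now.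

Compound 4 `O=c1ccc2cc(OCc3cc(-c4ccc(Cl)cc4)no3)ccc2o1` is compound 2 with one change, phenyl to 4-chlorophenyl: chloro in place of hydrogen on an aromatic carbon. The chloro stands on an aromatic carbon, para to a large group. With no number for compound 2, the step in this assay cannot be sized from the data. It is expected to be small, probably none beyond the usual scatter, and no direction is favoured. The expectation for compound 4 is therefore a value of the same general order as that of compound 3 at 51500 nM and not a sharp gain.

For compound 4 the estimated value is 40000 nM with an expected range from 12000 nM to 100000 nM (estimated, not measured).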

Compound 4, half-maximal inhibitory concentration: 55800 nM
Estimate against measurement, compound 4: 1.4-fold (0.14 log units) below; measured number inside the range.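

Within the data shown here, compound 2 has no single number, so no step to compound 4 at 55800 nM can be read. The compounds shown leave open what phenyl to 4-chlorophenyl does to the read-out. Nothing shown bears on this result.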